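Phenoxy for Pyridinyl: Expected Shift in Kinase Inhibition

The source may report more compounds than this note shows. Statements on the series, on what has been measured and on what is new or still open speak of the compounds shown alone.

Of the compounds shown here, two have so far been measured in an assay for inhibition of inositol hexakisphosphate kinase 3 (Homo sapiens), read by colorimetric assay, coupled enzyme assay and malachite green, with a stated time of 120 min, in the presence of a further agent that is not named here; on this read-out higher numbers stand for weaker inhibition and lower numbers for stronger inhibition. Compound 1 `O=C(O)/C=C/c1ccc2noc(-c3ccc(-c4ccccc4)cc3)c2c1` gives 200 nM. Compound 2 `O=C(O)c1ccc2noc(-c3ccc(-c4ccncc4)cc3)c2c1` gives 670 nM, the higher of the two numbers, and the gap between compound 1 and compound 2 lies beyond the usual scatter of repeated measurements.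

Compound 3 `O=C(O)c1ccc2noc(-c3ccc(Oc4ccccc4)cc3)c2c1` differs from compound 2 in a single place: phenoxy in place of pyridin-4-yl on an aromatic carbon of a six-membered aromatic ring of carbon only, para to a large group. Within the data shown here, no measured pair shows this exact change, so the size of the step is uncertain. Compound 3 is therefore expected to give 450 nM, within a range from 150 nM to 1500 nM. The step expected is a 1.5-fold lower number from compound 2 to compound 3 (0.17 log units; within the scatter), a modest move toward stronger inhibition that may not exceed the scatter.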

Compound 3, half-maximal inhibitory concentration: 550 nM
Compound 3: middle estimate off by 1.2-fold (0.09 log units), on the low side; measured number inside the range.
By their numbers in this assay, from the lowest: compound 1; then compounds 3 and 2 (each within the scatter of the next).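

In this assay, the exchange of pyridin-4-yl for phenoxy on an aromatic carbon, para to a large group, gives a 1.2-fold lower number from compound 2 to compound 3 (0.09 log units; within the scatter), so this assay does not separate compound 2 from compound 3. Among these compounds, this is the first single-place step at this position, and it shows that a six-membered aromatic ring with a hetero atom and a phenoxy group read alike here, even though one enters through an oxygen link. The data offer no measured explanation for this closeness.

From the compounds shown here alone, whether an amine, a morpholine ring or a longer alkyl chain at this position would move the number beyond the scatter remains open. Compound 1 differs from compound 3 in more than one place, so its value cannot be tied to any single group.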